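Replacing the nitrile on the ether chain with an ethyl group

The source may report more compounds than this note shows. Statements on the series, on what has been measured and on what is new or still open speak of the compounds shown alone.

Of the compounds shown here, three share one core and have been tested in an assay on isolated protein for inhibition of leukotriene B4 receptor 1 (Homo sapiens), tested at 10 uM; a lower number here means less inhibition, a higher number more inhibition at the concentration tested (going by the name of the read-out). Compound 1 `CCCc1cc(C(C)=O)c(O)cc1OCCCCC#N` gives 84% in this assay. Compound 2 `CCCCCCc1cc(C(C)=O)c(O)cc1OCCCCC#N` gives 51%, and compound 3 `C=CCc1cc(C(C)=O)c(O)cc1OCCCC#N` gives 47%. Among the compounds with values here, the single step that changes one place, a number 33 percentage points lower from compound 1 to compound 2 (beyond the scatter), is large and lowers the inhibition. Compound 3 holds the smallest of the three numbers, but the gap to compound 2 lies within the usual scatter, so only the gap to compound 1 separates them clearly.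

Compound 4 `C=CCc1cc(C(C)=O)c(O)cc1OCCCCC` differs from compound 3 by ethyl in place of cyano on a saturated chain carbon, three bonds along the chain from an oxygen on an aromatic ring. Within the data shown here, no measured step touches this part of the molecule: the one step on record alters the hydrocarbon group on the ring, not the end of the ether chain, so it gives no guidance on swapping a cyano for an ethyl. With nothing to lean on, the expectation is a step of no clear direction, a number 2 percentage points lower from compound 3 to compound 4 (within the scatter), and the uncertainty is wide. Compound 4 is therefore estimated at 45% in this assay, with a range from 20% to 70%.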

Compound 4, a percentage reported as inhibition, at one concentration (the size of the read-out at that concentration, not a potency): 60%
Estimate against measurement, compound 4: 15 percentage points below; the range from low to high includes it.
By their numbers in this assay, from the lowest: compounds 3, 2 and 4 (each within the scatter of the next, the first and the last beyond it); then compound 1.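

At the end of the ether chain, the change from 3-cyanopropyl to pentyl gives a number 13 percentage points higher from compound 3 to compound 4 (beyond the scatter) in this assay, which shows that the end of this chain can alter the read-out, not only the hydrocarbon group on the ring. The nitrile is also not required for inhibition in this pair: compound 4, whose chain is all carbon and has no hydrogen-bond acceptor at its end, still inhibits at the tested concentration, and the step is modest rather than large. No measurement shown here explains why the ethyl-for-cyano swap moves the number in this direction.

From the compounds shown here alone, it remains open whether the same swap would shift the number in the same direction on the core of compound 1, since a step seen on one core need not carry over to another. It is also unclear how a carboxylic acid or an amine at the end of the chain would compare with the nitrile and the pentyl chain, or whether a longer chain would take the number further in either direction.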